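This account rests on a few compounds, and the source may have more. Where it says the series, first, only, none or still open, it means among the compounds named here.

In a functional assay on A498 cells (Homo sapiens) for cytotoxicity (a higher number here means a weaker inhibitor of growth, a lower number a stronger inhibitor of growth), compound 3 (`COc1ccc(C2=C(c3ccc(SC)cc3)CC3CCCN3C2=O)cc1`) gives 800 nM, within the scatter of compound 1 (`COc1ccc(C2=C(c3ccc(SC)cc3)CC3CCCN3C2=O)cc1C`) at 400 nM, while compound 2 (`CSc1ccc(C2=C(c3ccc(F)c(F)c3)C(=O)N3CCCC3C2)cc1`) gives 100 nM. Compound 4 (`CSc1ccc(C2=C(c3ccc(O)cc3)C(=O)N3CCCC3C2)cc1`) differs from compound 3 by hydrogen in place of methyl on an oxygen on an aromatic ring, methoxy to hydroxy. Going by the values given here, no measured step covers this exact change. The closest evidence is an 8.0-fold higher number from compound 2 to compound 3 (0.90 log units; beyond the scatter), with 4-methoxyphenyl in place of 3,4-difluorophenyl, a modest step for a larger change. Hydrogen in place of methyl on an aromatic carbon gave a 2.0-fold higher number from compound 1 to compound 3 (0.30 log units; within the scatter), which stays within the scatter. An estimated 1.3-fold higher number from compound 3 to compound 4 (0.10 log units; within the scatter) is expected, so no step beyond the scatter is foreseen in this assay. Compound 4 is expected at 1000 nM, with an estimated range of 300 nM to 4000 nM.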

Compound 4, concentration for 50% growth inhibition: > 100000 nM
Compound 4: a limit, no number; the forecaster's own chance of this, stated with the estimate: 5%; middle value at least 100-fold (2.00 log units) away from the limit.
By their numbers in this assay, from the lowest: compound 2; then compounds 1 and 3 (each within the scatter of the next). At a limit, above all of these: compound 4.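

Compound 4 stands at a limit, not a number: the limit of > 100000 nM in this assay, at which 1 of the 4 values shown sits. In this assay, methoxy to hydroxy gives an at least 120-fold higher number from compound 3 to compound 4 (2.09 log units; beyond the scatter), so the methyl on this oxygen counts for far more than the earlier changes on this aryl group suggested. The gap is wider still from the other two compounds, with an at least 250-fold higher number from compound 1 to compound 4 (2.39 log units; beyond the scatter) and an at least 1000-fold higher number from compound 2 to compound 4 (3.00 log units; beyond the scatter).

Open, from the compounds shown here alone, is whether the free hydroxy or only the lost methyl sets this step. An ethoxy, an amino group or a carboxylic acid at this place would help separate the two.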